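Lengthening the Sulfonyl Side Chain toward a Terminal Hydroxyl

A few compounds are considered here, and "the series" means these few. Any claim that something is new, unique, unknown or untested is made for them only; others in the source may bear on it.

Measured so far:
compound 1 `C=CCCCCCCS(=O)(=O)/C=C/c1ccc(O)c(O)c1`: 6400 nM
compound 2 `O=S(=O)(/C=C/c1ccc(O)c(O)c1)CC1CCCC1`: 9400 nM

In a functional assay, read by fluorescence and spectrophotometry, with a stated time of 1 h (on this read-out lower numbers stand for an effect already at smaller amounts and higher numbers for an effect only at larger amounts of compound), compound 1 gives 6400 nM and compound 2 gives 9400 nM. Compound 1 has the lowest of the two numbers, but the step of a 1.5-fold higher number from compound 1 to compound 2 (0.17 log units; within the scatter) means the two cannot be told apart. Within the data shown here, that step, cyclopentyl in place of hept-6-en-1-yl on a saturated chain carbon bound to a sulfonyl sulfur, is the only comparison available, and it shows that reshaping the group on the sulfonyl sulfur barely moves the read-out while the shared core is kept.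

Compound 3 `O=S(=O)(/C=C/c1ccc(O)c(O)c1)CCCCCCCCCCCO` differs from compound 1 by 5-hydroxypentyl in place of vinyl on a saturated chain carbon, six bonds along the chain from a sulfonyl sulfur. Among the measured compounds shown here, no measured step adds a hydroxyl to this chain, so the one step is only a loose guide. Since that step from compound 1 to compound 2 stayed within the scatter, the expected step of a 1.1-fold higher number from compound 1 to compound 3 (0.04 log units; within the scatter) in this assay is also no more than the scatter. Compound 3 is therefore estimated at 7000 nM, with a range from 3000 nM to 16000 nM.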

Compound 3, half-maximal effective concentration: 22600 nM
Compound 3: the middle estimate sits 3.2-fold (0.51 log units) below what was measured, and the stated range ends below it.
By their numbers in this assay, from the lowest: compounds 1 and 2 (each within the scatter of the next); then compound 3.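

In this assay, putting 5-hydroxypentyl in place of vinyl at this place on the chain gives a 3.5-fold higher number from compound 1 to compound 3 (0.55 log units; beyond the scatter), so the far end of the group on the sulfonyl sulfur is not as free to change as the earlier comparison alone suggested, where the step of a 1.5-fold higher number from compound 1 to compound 2 (0.17 log units; within the scatter) could not be told apart from noise. The new step also changes several things at once: the double bond leaves, the chain grows longer, and a hydroxyl enters at its end, so this single comparison cannot assign the higher number to any one of them. Nothing available here explains the shift in the read-out.

The compounds shown leave open whether the extra length or the terminal hydroxyl matters more, a question that a chain of the same length ending in a plain methyl, or a shorter chain ending in a hydroxyl, could separate. They also leave open how this position would respond to a different end group on the long chain, such as an amine or a carboxylic acid.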